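The source may report more compounds than this note shows. Statements on the series, on what has been measured and on what is new or still open speak of the compounds shown alone.

Working notes on the series. Compound 1 `N#Cc1cccc(-n2cc(-c3ccc(/C=C4\C(=O)Nc5ccccc54)cc3)nn2)c1` is the reference point of the set. In a functional assay on HT-29 cells (Homo sapiens) for inhibition, read by CCK-8 assay, with a stated time of 24 h (on this read-out lower numbers stand for stronger inhibition and higher numbers for weaker inhibition), compound 1 gives only a limit of the assay, > 20000 nM. Compound 2 `O=C1Nc2ccccc2/C1=C/c1ccc(-c2cn(-c3ccc(Cl)c(C(F)(F)F)c3)nn2)cc1` carries 4-chloro-3-(trifluoromethyl)phenyl in place of 3-cyanophenyl on an aromatic nitrogen. In this assay compound 2 gives 9670 nM, which amounts to an at least 2.0-fold lower number from compound 1 to compound 2 (0.31 log units; beyond the scatter). Compound 3 `N#Cc1cccc(-n2cc(-c3ccc(/C=C4\C(=O)Nc5ccc(F)cc54)cc3)nn2)c1` differs from compound 1 only in the core, by fluoro in place of hydrogen on an aromatic carbon. In this assay compound 3 again gives only a limit of the assay, > 20000 nM. The step between these two is a step that the two limits leave unreadable from compound 1 to compound 3 because of the limit of > 20000 nM in this assay, at which 2 of the 3 values shown sit.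

Compound 4 `O=C1Nc2ccc(F)cc2/C1=C/c1ccc(-c2cn(-c3ccc(Cl)c(C(F)(F)F)c3)nn2)cc1` has not yet been measured. For the measured compounds named here, it differs from compound 3 by 4-chloro-3-(trifluoromethyl)phenyl in place of 3-cyanophenyl on an aromatic nitrogen, the same change as the one from compound 1 to compound 2, here made on the core of compound 3, and the surroundings of the place are described in identical words in both cases. Since the earlier change produced an at least 2.0-fold lower number from compound 1 to compound 2 (0.31 log units; beyond the scatter), a step of similar direction is expected, namely an at least 2.0-fold lower number from compound 3 to compound 4 (0.30 log units; that floor lies within the scatter). The estimate for compound 4 in this assay is 10000 nM, expected to lie between 4000 nM and 25000 nM.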

Compound 4, half-maximal inhibitory concentration: 16500 nM
Compound 4: the middle estimate sits 1.7-fold (0.22 log units) below what was measured, and the stated range covers the measured number.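

In this assay, 4-chloro-3-(trifluoromethyl)phenyl in place of 3-cyanophenyl on the fluoro-bearing core gives an at least 1.2-fold lower number from compound 3 to compound 4 (0.08 log units; that floor lies within the scatter), so the second core does not contradict the direction seen on the core of compound 1, but it does not establish a real gain either, and the sizes cannot be compared: the same change on two cores in this assay, an at least 2.0-fold lower number (0.31 log units; beyond the scatter) from compound 1 to compound 2 and an at least 1.2-fold lower number (0.08 log units; that floor lies within the scatter) from compound 3 to compound 4; the limit leaves it open whether they differ. Fluoro in place of hydrogen on the shared core, with 4-chloro-3-(trifluoromethyl)phenyl kept, gives a 1.7-fold higher number from compound 2 to compound 4 (0.23 log units; within the scatter), so with this group the two cores are not told apart in this assay. The same fluoro step with 3-cyanophenyl kept cannot be read, and transfer of the change is shown as compatible with both cores, not as equal in size on them: the limit of > 20000 nM in this assay, at which 2 of the 4 values shown sit.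

Open, going by these compounds, is whether an aliphatic amine or a carboxylic acid on the phenyl ring, or a longer alkyl chain on the aromatic nitrogen in its place, would move the number well beyond the scatter in this assay. Also open, on these data alone, is whether the change carries over to a core with chloro or methoxy in place of fluoro.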